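This account rests on a few compounds, and the source may have more. Where it says the series, first, only, none or still open, it means among the compounds named here.

Measured so far:
compound 1 `CCO/N=C(\CCN1CCN(c2ccccc2OC)CC1)c1ccccc1`, 76%
compound 2 `CCO/N=C(\CCN1CCN(c2ccc(OC)cc2)CC1)c1ccccc1`, 5%
compound 3 `CCO/N=C(\CCN1CCN(c2ncccc2C#N)CC1)c1ccccc1`, 64%

In a functional assay on HEK293 cells with D(4) dopamine receptor (Homo sapiens) as the target, read by FLIPR (a lower number here means a smaller maximal response, a higher number a larger maximal response), compound 3 stands second highest of the three numbers. Its nearest neighbour is compound 1, the step being a number 12 percentage points lower from compound 1 to compound 3 (beyond the scatter), a modest one; the furthest is compound 2, the step being a number 59 percentage points higher from compound 2 to compound 3 (beyond the scatter), a large one. The other step, a number 71 percentage points lower from compound 1 to compound 2 (beyond the scatter), is also large. All three steps exchange the whole aryl group on the amine nitrogen of the ring, so the series shows that this part of the molecule can move the maximal response a long way.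

Compound 4 `CCO/N=C(\CCN1CCN(c2ncccc2C)CC1)c1ccccc1` keeps the ring of compound 3 and differs from it by methyl in place of cyano on an aromatic carbon. Within the data shown here, no measured step alters a substituent on that ring while the ring itself is kept, so nothing bears directly on this change. Among the measured compounds shown here, the three steps seen all involve a larger exchange than the one in compound 4, and the two steps that keep a 2-substituted ring (those of compound 1 and compound 3) are modest against each other. A small to modest step, direction uncertain but somewhat more likely downward, is therefore expected, a number 9 percentage points lower from compound 3 to compound 4 (within the scatter). Compound 4 is estimated at 55%, range 25% to 80%.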

Compound 4, largest response reached (reported as efficacy), in percent of the reference or control that the assay uses: 49%
Compound 4: middle estimate off by 6 percentage points, on the high side; the range from low to high includes it.
By their numbers in this assay, from the lowest: compound 2; then compound 4; then compound 3; then compound 1.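

In this assay, the exchange of cyano for methyl at this place gives a number 15 percentage points lower from compound 3 to compound 4 (beyond the scatter), which shows that a single substituent on the kept ring, on an aromatic carbon two atoms from the ring nitrogen, moves the maximal response beyond the scatter, though only by a modest step. The 3-methylpyridin-2-yl group still sits well clear of the 4-methoxyphenyl group, with a number 44 percentage points higher from compound 2 to compound 4 (beyond the scatter), and short of the 2-methoxyphenyl group, with a number 27 percentage points lower from compound 1 to compound 4 (beyond the scatter), so the response at this aryl position depends on the ring substituent as well as on the ring, and cyano and methyl both leave the response at an intermediate level. Nothing available accounts for the change in maximal response at this place.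

Still open, from the compounds shown here alone, is how other groups at the same aromatic carbon, such as chlorine, methoxy or an amine, would rank against cyano and methyl. Also open, going by these compounds, is what the ring nitrogen contributes, which a 2-methylphenyl or 2-cyanophenyl group on the amine nitrogen of the ring would separate from the effect of the substituent.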